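Trimming a Methyl from the Dimethylphenyl Arm

The compounds below may be only part of what the source reports. "The series", "measured", "known", "first", "only" and "open" are said of these compounds alone.

Among the measured compounds shown here, compound 2 `COc1cc(-c2ccnc3cc(-c4ccc(C)c(C)c4)nn23)cc(OC)c1OC` stands at the low end of the two numbers measured so far: in a functional assay on MCF7 cells (Homo sapiens) for inhibition, read by CCK-8 assay, with a stated time of 48 h (on this read-out lower numbers stand for stronger inhibition and higher numbers for weaker inhibition), compound 2 gives 26 nM. For the measured compounds named here, compound 1 `COc1cc(-c2ccnc3cc(-c4ccc5cnn(C)c5c4)nn23)cc(OC)c1OC` sits well above it, as in this assay compound 1 gives 279 nM, and the single measured step, an 11-fold lower number from compound 1 to compound 2 (1.03 log units; beyond the scatter), came with a swap of the whole aryl arm. Compound 3 `COc1cc(-c2ccnc3cc(-c4cccc(C)c4)nn23)cc(OC)c1OC` differs from compound 2 by hydrogen in place of methyl on an aromatic carbon. Going by the values given here, no measured step removes or adds one methyl on this ring, so the known step bears on it only loosely: it shows that the identity of this arm matters, not what one methyl contributes. A small shift is therefore expected, with a 1.5-fold higher number from compound 2 to compound 3 (0.19 log units; within the scatter) judged to lie within the scatter, a modest loss being somewhat more likely than a gain. Compound 3 is expected to give about 40 nM in this assay, within a range of 15 nM to 110 nM.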

Compound 3, half-maximal inhibitory concentration: 1080 nM
For compound 3 the middle estimate is 27-fold (1.43 log units) below the measured one, outside the stated range (above it).
By their numbers in this assay, from the lowest: compound 2; then compound 1; then compound 3.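

In this assay, a single methyl on this ring proves decisive: going from the 3,4-dimethylphenyl arm to the 3-methylphenyl arm gives a 42-fold higher number from compound 2 to compound 3 (1.62 log units; beyond the scatter). The earlier step had swapped the whole arm, whereas this one isolates one carbon, and a 3.9-fold higher number from compound 1 to compound 3 (0.59 log units; beyond the scatter) shows that the 3-methylphenyl arm also falls behind the 1-methyl-1H-indazol-6-yl arm, so the place of the 1-methyl-1H-indazol-6-yl arm in the order depends on which phenyl arm it is set against. Nothing available here explains why one methyl counts for so much.

The compounds shown leave open whether a chlorine atom, a methoxy group or an ethyl group on this carbon would keep the low number of compound 2 or follow compound 3. They also leave open how much the remaining methyl contributes.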